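Halophenyl swap carried onto the fluorinated core

The compounds below may be only part of what the source reports. "The series", "measured", "known", "first", "only" and "open" are said of these compounds alone.

Working notes on the series. Compound 1 `O=C(Nc1ccc(Oc2ccnc3[nH]ccc23)cc1)c1cc2cccnc2n(-c2ccc(F)c(Cl)c2)c1=O` in a functional assay on A549 cells (Homo sapiens) for antiproliferative activity, read by MTT assay, with a stated time of 72 h (on this read-out higher numbers stand for weaker inhibition and lower numbers for stronger inhibition), gives 680 nM. Compound 2 `O=C(Nc1ccc(Oc2ccnc3[nH]ccc23)cc1)c1cc2cccnc2n(-c2ccc(Br)cc2F)c1=O` gives 1570 nM in this assay. Compound 3 `O=C(Nc1ccc(Oc2ccnc3[nH]ccc23)c(F)c1)c1cc2cccnc2n(-c2ccc(F)c(Cl)c2)c1=O` gives 630 nM in this assay, the lowest of the three numbers, though its gap to compound 1 lies within the scatter. Compound 4 `O=C(Nc1ccc(Oc2ccnc3[nH]ccc23)c(F)c1)c1cc2cccnc2n(-c2ccc(Br)cc2F)c1=O` has not yet been measured.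

The change from compound 1 to compound 2 is 4-bromo-2-fluorophenyl in place of 3-chloro-4-fluorophenyl on an aromatic nitrogen and it made a 2.3-fold higher number from compound 1 to compound 2 (0.36 log units; beyond the scatter). The two cores differ by fluoro in place of hydrogen on an aromatic carbon, which made a 1.1-fold lower number from compound 1 to compound 3 (0.03 log units; within the scatter). The change from compound 3 to compound 4 is 4-bromo-2-fluorophenyl in place of 3-chloro-4-fluorophenyl on an aromatic nitrogen, the same change as between compound 1 and compound 2, and it occurs twice among these compounds.

For compound 4 a step of a 2.3-fold higher number from compound 3 to compound 4 (0.36 log units; beyond the scatter) in this assay is expected. Within the data shown here, this rests on the single earlier instance, because a 2.3-fold higher number from compound 1 to compound 2 (0.36 log units; beyond the scatter) is the only guide to this change, and on the cores behaving alike so far, because a 1.1-fold lower number from compound 1 to compound 3 (0.03 log units; within the scatter) lies within the scatter. Compound 4 is therefore estimated at 1450 nM, with a range from 750 nM to 2900 nM.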

Compound 4, half-maximal inhibitory concentration: 460 nM
Compound 4: the middle estimate sits 3.2-fold (0.50 log units) above what was measured; measured number below the stated range.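

The 4-bromo-2-fluorophenyl swap does not carry over unchanged between cores: in this assay it gives a 1.4-fold lower number from compound 3 to compound 4 (0.14 log units; within the scatter), and the penalty seen on the core of compound 1 does not return on the fluorinated core: the same change on two cores in this assay, a 2.3-fold higher number (0.36 log units; beyond the scatter) from compound 1 to compound 2 and a 1.4-fold lower number (0.14 log units; within the scatter) from compound 3 to compound 4, 3.2-fold (0.50 log units) apart, beyond the scatter of two such steps Read the other way, the added fluoro on the aromatic carbon gives a 3.4-fold lower number from compound 2 to compound 4 (0.53 log units; beyond the scatter) with the 4-bromo-2-fluorophenyl group, but makes no difference beyond the scatter with the 3-chloro-4-fluorophenyl group: the same change on two cores in this assay, a 1.1-fold lower number (0.03 log units; within the scatter) from compound 1 to compound 3 and a 3.4-fold lower number (0.53 log units; beyond the scatter) from compound 2 to compound 4, 3.2-fold (0.50 log units) apart, beyond the scatter of two such steps The two changes therefore do not add independently in these compounds, but this is a single set of two cores and two aryl groups, so it shows neither why they interact nor how general the interaction is.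

Going by these compounds, it remains open whether other aryl groups on the aromatic nitrogen, such as plain phenyl or 4-methoxyphenyl, also depend on the core in this way. On these data alone, it is equally open whether chloro or methoxy in place of the added fluoro would give the same result.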